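This account rests on a few compounds, and the source may have more. Where it says the series, first, only, none or still open, it means among the compounds named here.

In a functional assay on MKN-45 cells (Homo sapiens) for cytotoxicity (on this read-out lower numbers stand for stronger inhibition and higher numbers for weaker inhibition), the measured compounds read as follows
compound 1 `COc1ccc(S(=O)(=O)N2CCc3cccc(NC(=O)c4cccs4)c32)cc1` gives 31 nM
compound 2 `COc1ccc(S(=O)(=O)N2CCc3cccc(NC(=O)c4ccc(F)cc4)c32)cc1` gives 45 nM
compound 3 `COc1ccc(S(=O)(=O)N2CCc3cccc(NC(=O)c4ccco4)c32)cc1` gives 10.7 nM

Compound 3 has the lowest number of the three, with a 2.9-fold lower number from compound 1 to compound 3 (0.46 log units; beyond the scatter) and a 4.2-fold lower number from compound 2 to compound 3 (0.62 log units; beyond the scatter) as its two gaps. Compound 4 `COc1ccc(S(=O)(=O)N2CCc3cccc(N)c32)cc1` has hydrogen in place of (furan-2-yl)carbonyl on a nitrogen on an aromatic ring and so loses the whole group. The measured steps, the third being a 1.5-fold higher number from compound 1 to compound 2 (0.16 log units; within the scatter), only exchange what sits on the carbonyl carbon, so they guide loosely. Removing the whole group is a bigger edit, so a rise larger than these steps is expected in this assay here. The estimated step is a 28-fold higher number from compound 3 to compound 4 (1.45 log units; beyond the scatter) and it stays uncertain. For compound 4 the estimated value is 300 nM within an expected range from 40 nM to 3000 nM until it is measured.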

Compound 4, half-maximal inhibitory concentration: 1200 nM
Compound 4: the middle estimate sits 4.0-fold (0.60 log units) below what was measured; the measured number falls inside the stated range.
By their numbers in this assay, from the lowest: compound 3; then compounds 1 and 2 (each within the scatter of the next); then compound 4.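

Taking the whole group off this nitrogen changes the number in this assay far more than any exchange on the carbonyl carbon did, whichever compound it is removed from (a 110-fold higher number from compound 3 to compound 4 (2.05 log units; beyond the scatter)), (a 27-fold higher number from compound 2 to compound 4 (1.43 log units; beyond the scatter)) and (a 39-fold higher number from compound 1 to compound 4 (1.59 log units; beyond the scatter)). Among these four compounds, then, having a ring-bearing carbonyl group on the amino nitrogen counts for more than which of the three rings it carries. Nothing measured here explains this loss.

Still open, from the compounds shown here alone, is whether the carbonyl alone or the ring on it accounts for the difference. An acetyl group on this nitrogen would help separate the two.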